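Compound 2 and a Hydroxyphenyl Replacement

A few compounds are considered here, and "the series" means these few. Any claim that something is new, unique, unknown or untested is made for them only; others in the source may bear on it.

In a functional assay on MGC-803 cells (Homo sapiens) for antiproliferative activity, read by CellTiter-Glo, with a stated time of 72 h (on this read-out higher numbers stand for weaker inhibition and lower numbers for stronger inhibition), the measured compounds stand as follows:
Compound 1 `O=C(NO)c1ccc(/C=C/c2ccnc(-c3cc(F)ccc3O)c2)cc1`: 1920 nM
Compound 2 `COc1ccccc1-c1cc(/C=C/c2ccc(C(=O)NO)cc2)ccn1`: 6350 nM

Within the data shown here, compound 2 at 6350 nM holds the higher of the two numbers, with compound 1 as its only neighbour. Compound 3 `O=C(NO)c1ccc(/C=C/c2ccnc(-c3cccc(O)c3)c2)cc1` has not yet been measured. Against compound 2, the difference 3-hydroxyphenyl in place of 2-methoxyphenyl on an aromatic carbon puts 3-hydroxyphenyl in place of 2-methoxyphenyl on an aromatic carbon, next to the ring nitrogen. Among the measured compounds shown here, the only measured step bearing on this is a 3.3-fold higher number from compound 1 to compound 2 (0.52 log units; beyond the scatter) for 2-methoxyphenyl in place of 5-fluoro-2-hydroxyphenyl. Compound 3 also lacks the 2-methoxyphenyl, but its 3-hydroxyphenyl is not the 5-fluoro-2-hydroxyphenyl of compound 1, so that step is only a partial guide. Compound 1 at 1920 nM is the sole measured reference carrying a hydroxyphenyl, so a modest step to a lower number in this assay is expected, no larger than the measured one. The estimated change is a 2.4-fold lower number from compound 2 to compound 3 (0.39 log units; beyond the scatter) and remains an expectation. For compound 3 the estimate is 2600 nM with 1000 nM to 6500 nM as its expected range.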

Compound 3, half-maximal inhibitory concentration: 2100 nM
The estimate for compound 3 lay 1.2-fold (0.09 log units) above the measured number, within the range that was stated.
By their numbers in this assay, from the lowest: compounds 1 and 3 (each within the scatter of the next); then compound 2.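

In this assay, 3-hydroxyphenyl in place of 2-methoxyphenyl on the aromatic carbon next to the ring nitrogen gives a 3.0-fold lower number from compound 2 to compound 3 (0.48 log units; beyond the scatter) and thus shows that the lower number at this position does not depend on the 5-fluoro-2-hydroxyphenyl group of compound 1. Exchanging that group for 3-hydroxyphenyl gives a 1.1-fold higher number from compound 1 to compound 3 (0.04 log units; within the scatter) and so leaves no readable difference between the two hydroxyphenyl groups, even though they differ in both the fluoro substituent and the place of the hydroxyl; each of the two compounds carrying them has a number beyond the scatter from that of compound 2. Nothing available accounts for the separation between the hydroxyphenyl groups and the 2-methoxyphenyl group.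

The change from compound 2 to compound 3 alters both the oxygen substituent and its place on the phenyl ring, so the compounds shown leave open which of the two matters, a question that 3-methoxyphenyl and unsubstituted 2-hydroxyphenyl partners would separate. Also open, going by these compounds, is how a phenyl ring carrying an amine or a carboxylic acid would read at this position in this assay and whether the fluoro substituent has any effect of its own when the hydroxyl stays in one place.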